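The source may report more compounds than this note shows. Statements on the series, on what has been measured and on what is new or still open speak of the compounds shown alone.

In an ADME assay on microsomes from liver (Mus musculus) for metabolic stability, with a stated time of 10 min (on this read-out higher numbers stand for a more stable compound and lower numbers for a less stable compound), compound 1 `CCC[C@]1(C(=O)N2CC[C@](c3ccc(C(F)(C(F)(F)F)C(F)(F)F)cc3)(S(=O)(=O)c3ccc(F)cc3)C2)CC[C@H](C(=O)O)CC1` has no number, its entry reading "not determined" (no result reported), so compound 2 `O=C(N1CC[C@](c2ccc(C(F)(C(F)(F)F)C(F)(F)F)cc2)(S(=O)(=O)c2ccc(F)cc2)C1)C1(O)CCS(=O)(=O)CC1`, at 90%, is the only measured reference. Compound 3 `O=C(N1CC[C@](c2ccc(C(F)(C(F)(F)F)C(F)(F)F)cc2)(S(=O)(=O)c2ccc(F)cc2)C1)C1(CO)CCS(=O)(=O)CC1` keeps the shared core and differs in one place: hydroxymethyl in place of hydroxy on a saturated ring carbon, with hydroxymethyl in place of hydroxy on a saturated ring carbon. Within the data shown here, no measured pair shows the effect of such a change, so only a small drop, within the scatter, is expected in this assay. The expected change is a number 6 percentage points lower from compound 2 to compound 3 (within the scatter). For compound 3, the estimated value is 84%, with an expected range of 68% to 95%.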

Compound 3, percent of the compound remaining: 31%
Estimate against measurement, compound 3: 53 percentage points above, and the stated range ends above it.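

In this assay, hydroxymethyl in place of hydroxy on this saturated ring carbon, three ring bonds from the ring sulfur, gives a number 59 percentage points lower from compound 2 to compound 3 (beyond the scatter). This first readable step shows that the group at this position can strongly change the read-out, even with the shared core otherwise untouched. Nothing available here accounts for the size of this step.

From the compounds shown here alone, whether an amine, a carboxylic acid or a longer chain such as hydroxyethyl on the same ring carbon would read closer to compound 2 or to compound 3 remains open. So does whether this step would recur on another core.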